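A bromo substituent added to a urotensin-2 receptor ligand

This account rests on a few compounds, and the source may have more. Where it says the series, first, only, none or still open, it means among the compounds named here.

Three compounds share the dichlorobenzamide-pyrrolidine core and were tested in an assay on HEK293 cells for displacement of a labelled ligand from Urotensin-2 receptor (Homo sapiens); on this read-out lower numbers stand for stronger inhibition and higher numbers for weaker inhibition. Compound 1 `CN(C)CCCOc1cccc(CN2CC[C@H](NC(=O)c3ccc(Cl)c(Cl)c3)C2)c1` reaches only the assay limit, reported as > 3000 nM. Compound 2 `CN(C)CCCOc1ccccc1CN1CC[C@H](NC(=O)c2ccc(Cl)c(Cl)c2)C1` likewise gives only a limit, > 10000 nM. For the measured compounds named here, compound 3 `CN1CCC(Oc2ccc(CN3CCC(NC(=O)c4ccc(Cl)c(Cl)c4)C3)cc2)C1` is the one member of the set with a measured number, and in this assay compound 3 gives 97 nM, so it stands as the sole numeric reference point among the three.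

The untested compound 4 `CN1CCC(Oc2ccc(CN3CCC(NC(=O)c4ccc(Cl)c(Cl)c4)C3)cc2Br)C1` differs from compound 3 in one place: bromo in place of hydrogen on an aromatic carbon. Going by the values given here, no measured pair in the set isolates such a change, so the size and direction of the step from compound 3 to compound 4 cannot be read from the data. The expectation is that the step of a 1.2-fold higher number from compound 3 to compound 4 (0.09 log units; within the scatter) stays within the ordinary scatter of this assay, with no clear movement in either direction. On that basis compound 4 is estimated at 120 nM, with a plausible range from 40 nM to 400 nM.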

Compound 4, inhibition constant: 41 nM
Estimate against measurement, compound 4: 2.9-fold (0.47 log units) above; measured number inside the range.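

In this assay, for the compounds shown here, bromo in place of hydrogen on an aromatic carbon, ortho to a (1-methylpyrrolidin-3-yl)oxy group, gives a 2.4-fold lower number from compound 3 to compound 4 (0.37 log units; beyond the scatter), the first single-place step that can be read in this set. Going by these compounds alone, it shows that this position accepts a bromine atom and that the number moves modestly towards stronger inhibition, which the earlier compounds could not show, as no two of them differed in one place. Nothing in the data shown bears on why the number falls.

The compounds shown leave open whether a chloro, methyl or methoxy group on the same carbon would give a similar step or whether the step is particular to bromo. They also leave open how bromo would behave on the other carbons of this ring.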